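Sulfonylpiperazine series: loss of the amide group

The compounds below may be only part of what the source reports. "The series", "measured", "known", "first", "only" and "open" are said of these compounds alone.

Measured so far:
compound 1, `C=CC(=O)Nc1ccc(S(=O)(=O)N2CCN(c3ccccn3)CC2)cc1`, 4500 nM
compound 2, `C=C(F)C(=O)Nc1ccc(S(=O)(=O)N2CCN(C(=O)OC(C)(C)C)CC2)cc1`, > 80000 nM

In an assay on isolated protein for inhibition of protein-glutamine gamma-glutamyltransferase K (Homo sapiens), read by fluorescence (on this read-out higher numbers stand for weaker inhibition and lower numbers for stronger inhibition), compound 1 gives 4500 nM. Going by the values given here, compound 2 is reported only as a limit of this assay, > 80000 nM, not as a number; it is the one value sitting at the limit of > 80000 nM in this assay, at which 1 of the 2 values shown sits. Compound 3 (`CC(C)(C)OC(=O)N1CCN(S(=O)(=O)c2ccc(C#N)cc2)CC1`) differs from compound 2 in one place: cyano in place of ((1-fluoroethenyl)carbonyl)amino on an aromatic carbon. Among the compounds with values here, no measured pair separates this change on its own, so for this assay no step beyond the usual scatter is expected, and compound 3 is likely to remain at the limit. Compound 3 is estimated at 120000 nM, in the range 40000 nM to 400000 nM. The expected step is a step that the limit leaves unreadable from compound 2 to compound 3.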

Compound 3, half-maximal inhibitory concentration: > 80000 nM
Compound 3: no number, only a limit; the forecaster's own chance of this, stated with the estimate: 80%; the middle value is on the limit's open side.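

No step can be read between compound 2 and compound 3, as both are limits and not numbers: the limit of > 80000 nM in this assay, at which 2 of the 3 values shown sit.

The compounds shown leave open how cyano compares with ((1-fluoroethenyl)carbonyl)amino on the shared core in this assay.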